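A few compounds are considered here, and "the series" means these few. Any claim that something is new, unique, unknown or untested is made for them only; others in the source may bear on it.

Compounds measured in an ADME assay on MT4 cells (Homo sapiens) for cytotoxicity, read by MTT assay, with a stated time of 4 days; on this read-out higher numbers stand for lower toxicity in this test and lower numbers for higher toxicity in this test:
compound 1, `CCCN(C)c1nc(Cc2c(F)cccc2F)cc(=O)[nH]1`, gives 85000 nM.
compound 2, `O=c1cc(Cc2c(F)cccc2F)nc(N2CCCC2)[nH]1`, gives only the limit > 86000 nM.
compound 3, `CC1CCCN(c2nc(Cc3c(F)cccc3F)cc(=O)[nH]2)C1`, gives only the limit > 78000 nM.

Compound 3 thus stands at a limit of this assay and not at a number; the evidence for it is the limit of > 78000 nM in this assay, at which 1 of the 3 values shown sits. Compound 2 likewise sits at a limit, (the limit of > 86000 nM in this assay, at which 1 of the 3 values shown sits). Only compound 1 gives a real number, and the move an at least 1.0-fold higher number from compound 1 to compound 2 (0.00 log units; that floor lies within the scatter) shows a floor that lies within the scatter. The moves a step that the limit leaves unreadable from compound 1 to compound 3 and a step that the two limits leave unreadable from compound 2 to compound 3 cannot be sized, since the limits hide them. All three measured compounds therefore read as low-toxicity in this assay with no resolved differences among them.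

Compound 4, `CN1CCN(c2nc(Cc3c(F)cccc3F)cc(=O)[nH]2)CC1`, is not yet measured. Its change from compound 3 is 4-methylpiperazin-1-yl in place of 3-methylpiperidin-1-yl on an aromatic carbon. For the measured compounds named here, no measured step involves this group, so the expectation rests only on the series sitting at or near the upper end of the assay window. The step expected is a step that the limit leaves unreadable from compound 3 to compound 4, which is none beyond the scatter. For compound 4 the estimated value in this assay is 90000 nM, with a range from 40000 nM to 200000 nM, and a limit rather than a number is the more likely outcome.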

Compound 4, half-maximal cytotoxic concentration: > 78000 nM
Compound 4 gave a limit, no number; the forecaster's own chance of this, stated with the estimate: 70%; the middle value does not contradict the limit.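

Compound 4 stands at a limit and not at a number, so the steps to it from compound 1, compound 2 and compound 3 cannot be read: the limit of > 78000 nM in this assay, at which 2 of the 4 values shown sit.

The compounds shown leave open whether compound 2, compound 3 and compound 4 differ from one another or from compound 1 in this assay.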